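Removing a Methyl from the Linking Nitrogen

The compounds below may be only part of what the source reports. "The series", "measured", "known", "first", "only" and "open" are said of these compounds alone.

Compound 3 `COc1ccc(N(C)c2nccc(-c3ccncc3)n2)cc1` reaches only the limit of a functional assay for inhibition, with Homo sapiens as the target (a higher number here means a weaker inhibitor, a lower number a stronger inhibitor), giving > 24000 nM. That limit, (the limit of > 24000 nM in this assay, at which 1 of the 3 values shown sits), is a boundary of the assay rather than a number. Compound 1 `CCc1ccc(Nc2nccc(-c3ccncc3)n2)cc1` and compound 2 `NS(=O)(=O)c1ccc(Nc2nccc(-c3ccncc3)n2)cc1` both carry hydrogen on the linking nitrogen; in this assay compound 1 gives 7700 nM and compound 2 gives 5100 nM, and the step of a 1.5-fold lower number from compound 1 to compound 2 (0.18 log units; within the scatter) lies within the scatter. Compound 4 `COc1ccc(Nc2nccc(-c3ccncc3)n2)cc1` differs from compound 3 by hydrogen in place of methyl on a nitrogen on an aromatic ring. Among the compounds with values here, no measured step covers exactly this change, yet both compounds with hydrogen there give numbers while compound 3 does not, so a lower number in this assay is expected, beyond the scatter. Compound 4 is therefore estimated at 7000 nM, between 3000 nM and 20000 nM, an expected step of an at least 3.4-fold lower number from compound 3 to compound 4 (0.53 log units; beyond the scatter).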

Compound 4, half-maximal inhibitory concentration: 4200 nM
The estimate for compound 4 lay 1.7-fold (0.22 log units) above the measured number, within the range that was stated.
By their numbers in this assay, from the lowest: compounds 4, 2 and 1 (each within the scatter of the next). At a limit, above all of these: compound 3.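

Hydrogen in place of methyl on a nitrogen on an aromatic ring gives an at least 5.7-fold lower number from compound 3 to compound 4 (0.75 log units; beyond the scatter) in this assay, the first direct reading of this change. As far as these compounds go, its full size stays unknown, since compound 3 stands at a limit of the assay: the limit of > 24000 nM in this assay, at which 1 of the 4 values shown sits. Methoxy in place of sulfamoyl gives a 1.2-fold lower number from compound 2 to compound 4 (0.08 log units; within the scatter), and methoxy in place of ethyl gives a 1.8-fold lower number from compound 1 to compound 4 (0.26 log units; within the scatter), so with hydrogen on this nitrogen these three groups are not told apart.

Still open, from the compounds shown here alone, is what an acetyl group on this nitrogen would give. Also open, going by these compounds, is whether a carboxylic acid in place of methoxy would stand apart from these three groups.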